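The compounds below may be only part of what the source reports. "The series", "measured", "known", "first", "only" and "open" are said of these compounds alone.

Working notes on a small set of thieno-fused amines tested in an assay on isolated protein for inhibition of cytochrome P450 2A6 (Homo sapiens), read by fluorescence, with a stated time of 10 min; on this read-out lower numbers stand for stronger inhibition and higher numbers for weaker inhibition.

Three compounds have numbers. Compound 1, `CNCc1cc2cnccc2s1`, gives 1500 nM in this assay. Compound 2, `NCc1csc2ccc(Br)cc12`, gives 700 nM in this assay. Compound 3, `NCc1cc2ccncc2s1`, gives 5200 nM in this assay. Among these three numbers compound 1 stands second highest: the nearest is compound 2, whose lower number lies beyond the scatter, and the furthest is compound 3, whose higher number also lies beyond the scatter. Within the data shown here, no two of the measured compounds differ in only one place, so no single step has been measured in this assay.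

The next compound, compound 4, is `NCc1cc2cnccc2s1`. Against compound 1 the difference is hydrogen in place of methyl on an amine nitrogen, that is, methylamino to amino, or (methylamino)methyl to aminomethyl. Among the measured compounds shown here, nothing among the measured compounds shows this exact change on the same core; compound 2 and compound 3 carry the aminomethyl group on other cores, and their numbers bracket compound 1 on both sides. The expectation is therefore a step from compound 1 to compound 4 of a 1.3-fold higher number from compound 1 to compound 4 (0.12 log units; within the scatter), a small move, if any, beyond the scatter. Compound 4 is expected to give about 2000 nM in this assay, within a range from 800 nM to 5000 nM.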

Compound 4, half-maximal inhibitory concentration: 1000 nM
For compound 4 the middle estimate is 2.0-fold (0.30 log units) above the measured one, within the range that was stated.
By their numbers in this assay, from the lowest: compounds 2, 4 and 1 (each within the scatter of the next, the first and the last beyond it); then compound 3.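

Among these compounds, this is the first single change measured. In this assay, hydrogen in place of methyl on an amine nitrogen whose other neighbour is a saturated chain carbon gives a 1.5-fold lower number from compound 1 to compound 4 (0.18 log units; within the scatter), so on this core the read-out does not separate the (methylamino)methyl group from the aminomethyl group. Among the compounds shown here, at this position, the methyl group can therefore be present or absent without a change that stands clear of the usual scatter, a point that the earlier compounds, with no single step among them, could not show. No measured evidence bears on this result, so the step stands as an observation without an explanation.

Still open, going by these compounds, is whether a larger group on the same amine nitrogen, such as ethyl, a longer chain or an acetyl group, or a second methyl giving a dimethylamino group, would stay equally close to these two compounds. Also open, on these data alone, is whether the same exchange of methyl for hydrogen would give a similarly small step on the cores of compound 2 and compound 3.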